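A few compounds are considered here, and "the series" means these few. Any claim that something is new, unique, unknown or untested is made for them only; others in the source may bear on it.

Working notes on the series.

Three members of the series have been run in a functional assay on CHO cells for agonist activity at Free fatty acid receptor 1 (Homo sapiens), read by FLIPR and calcium flux; a higher number here means that more compound is needed for the effect, a lower number that less compound is needed. Compound 1 `O=C(O)COc1ccc(NCc2cccc(-c3ccccc3F)c2)cc1F` gives 36.5 nM. Compound 2 `Cc1ccc(-c2cccc(CNc3ccc(OCC(=O)O)c(F)c3)c2)c(Cl)c1` gives 22.5 nM. Compound 3 `CCOc1ccc(-c2cccc(CNc3ccc(OCC(=O)O)c(F)c3)c2)c(C)c1` gives 11.6 nM, the lowest of the three numbers. The step of a 3.1-fold lower number from compound 1 to compound 3 (0.50 log units; beyond the scatter) is the only one among these three that clears the scatter; the steps of a 1.6-fold lower number from compound 1 to compound 2 (0.21 log units; within the scatter) and a 1.9-fold lower number from compound 2 to compound 3 (0.29 log units; within the scatter) both lie within it, so compound 2 and compound 3 cannot be ordered against each other on these numbers.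

Compound 4 `COCCOc1ccc(-c2cccc(CNc3ccc(OCC(=O)O)c(F)c3)c2)c(C)c1` is the next member. Against compound 3 the difference is methoxy in place of hydrogen on a saturated chain carbon, two bonds along the chain from an oxygen on an aromatic ring; the ethoxy of compound 3 becomes 2-methoxyethoxy.

Among the measured compounds shown here, none of the measured steps touches this chain. For the measured compounds named here, the steps from compound 1 to compound 2 and to compound 3 exchange the whole distal aryl group, and the step from compound 2 to compound 3 does the same; no pair in the set varies only the chain on the aromatic oxygen. The expectation therefore rests on compound 3 alone. Going by the values given here, with no comparable step in hand, the expected change is a 1.3-fold higher number from compound 3 to compound 4 (0.11 log units; within the scatter), which is none beyond the scatter.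

Compound 4 is accordingly estimated at 15 nM in this assay, with a range from 5 nM to 45 nM.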

Compound 4, half-maximal effective concentration: 41.9 nM
Compound 4: the middle estimate sits 2.8-fold (0.45 log units) below what was measured, and the stated range covers the measured number.
By their numbers in this assay, from the lowest: compounds 3, 2, 1 and 4 (each within the scatter of the next, the first and the last beyond it).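

In this assay the chain on the aromatic oxygen proves to be a place where a small change registers by itself: 2-methoxyethoxy in place of ethoxy, with the rest of the structure untouched, gives a 3.6-fold higher number from compound 3 to compound 4 (0.56 log units; beyond the scatter), beyond the scatter. The earlier steps shown here all exchanged the whole distal aryl group, so they could not separate the contribution of this chain from that of the rest of that group; here, methoxy in place of hydrogen on a saturated chain carbon, two bonds along the chain from an oxygen on an aromatic ring, is the only difference and moves the number upward. No measurement in hand bears on the reason for this step.

Open, as far as these compounds go, is whether the higher number goes with the oxygen of the added methoxy or with the added chain length, a question that a plain butoxy chain at the same oxygen would address. Also open, from the compounds shown here alone, is how other end groups on this chain, such as a hydroxyl or a dimethylamino group, would read, and whether the same change gives a step of similar size on the 2-chloro-4-methylphenyl group of compound 2.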